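This account rests on a few compounds, and the source may have more. Where it says the series, first, only, none or still open, it means among the compounds named here.

Compound 1, `NC(=O)c1c(NC(=O)c2ccccc2Cl)sc2c1CCN(Cc1ccc([N+](=O)[O-])cc1)C2`: in a functional assay on MKN-74 cells (Homo sapiens) for antiproliferative activity, with a stated time of 24 h (a higher number here means a weaker inhibitor, a lower number a stronger inhibitor), compound 1 gives 31500 nM.
Compound 2, `NC(=O)c1c(NC(=O)c2ccccc2F)sc2c1CCN(Cc1cccc(Cl)c1)C2`: in this assay compound 2 gives 23300 nM.

Of these two numbers, compound 1 carries the higher one, but compound 2 lies within the usual scatter of it, so the two compounds cannot be told apart on this evidence. Compound 3, `COc1ccccc1NC(=S)N1CCc2c(sc(NC(=O)c3ccccc3Cl)c2C(N)=O)C1`, is not yet measured. It differs from compound 1 in one place: a group of 11 heavy atoms (8 carbon, 1 nitrogen, 1 oxygen, 1 sulfur; one six-membered aromatic ring of carbon only) in place of a group of 10 heavy atoms (7 carbon, 1 nitrogen, 2 oxygen; one six-membered aromatic ring of carbon only), on an amine nitrogen in a ring. Going by the values given here, no measured pair shows what such an exchange does in this assay, so the step of a 1.3-fold lower number from compound 1 to compound 3 (0.10 log units; within the scatter) is expected to be none beyond the scatter. Compound 3 is therefore estimated at 25000 nM, with a range from 5000 nM to 100000 nM.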

Compound 3, half-maximal inhibitory concentration: 35200 nM
Estimate against measurement, compound 3: 1.4-fold (0.15 log units) below; measured number inside the range.
By their numbers in this assay, from the lowest: compounds 2, 1 and 3 (each within the scatter of the next).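

Placing the sulfur-bearing group with its hydrogen-bond donor on the amine nitrogen in the ring, instead of 4-nitrobenzyl, gives a 1.1-fold higher number from compound 1 to compound 3 (0.05 log units; within the scatter) in this assay as the first direct comparison at this position. This exchange therefore leaves the antiproliferative reading indistinguishable, even though the two groups differ in their atoms and donor count. Nothing available explains this outcome.

The compounds shown leave open whether an aminoalkyl chain or a carboxylic acid on this nitrogen would move the number beyond the scatter. They also leave open whether this exchange behaves alike with other groups elsewhere on the shared core.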